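This account rests on a few compounds, and the source may have more. Where it says the series, first, only, none or still open, it means among the compounds named here.

Measured so far in a toxicity assay on NIH3T3 cells (Mus musculus) for cytotoxicity, read by resazurin assay; on this read-out lower numbers stand for an effect already at smaller amounts and higher numbers for an effect only at larger amounts of compound:
- compound 1, `COC(=O)c1ccc(NCc2cncn2Cc2ccccc2OC)cc1-c1ccccc1`: "not determined" (no result reported)
- compound 2, `c1ccc(-c2ccc(Cn3cncc3CNc3ccc(-c4ccc[nH]4)c(-c4ccccc4)c3)cc2)cc1`: > 10000 nM

Compound 1 carries no result in this assay. For compound 2 the entry in this assay is a limit of the assay, > 10000 nM, not a measured number; this is the situation described by the limit of > 10000 nM in this assay, at which 1 of the 2 values shown sits. Within the data shown here, with one entry missing and the other at a limit, no step between measured compounds can be drawn, and compound 2 is the only anchor for the next member of the series.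

Compound 3, `CCOC(=O)c1ccc(NCc2cncn2Cc2ccc(-c3ccccc3)cc2)cc1-c1ccccc1`, remains to be measured in this assay. Against compound 2 it differs in one place: ethoxycarbonyl in place of 1H-pyrrol-2-yl on an aromatic carbon. No measured shift in this assay is tied to this exchange anywhere in the series, and the single anchor, compound 2, sits at the limit. The expected step is therefore none beyond the scatter, a step that the limit leaves unreadable from compound 2 to compound 3, with the expectation that compound 3 again returns a limit rather than a number. Compound 3 is estimated at 15000 nM, within a range from 5000 nM to 50000 nM.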

Compound 3, half-maximal effective concentration: > 10000 nM
Compound 3 ended at the assay's limit; the forecaster's own chance of this, stated with the estimate: 65%; the middle value does not contradict the limit.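

In this assay, no step can be read from compound 2 to compound 3, since neither entry is a measured number: the limit of > 10000 nM in this assay, at which 2 of the 3 values shown sit.

The compounds shown leave open whether ethoxycarbonyl in place of 1H-pyrrol-2-yl shifts the read-out at all, and at what concentration either compound would reach a half-maximal effect.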